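A few compounds are considered here, and "the series" means these few. Any claim that something is new, unique, unknown or untested is made for them only; others in the source may bear on it.

Working notes on the series.

Compound 1 `O=c1ccoc2cc(OCc3cn(Cc4cccc(Br)c4)nn3)ccc12` is the reference point. In a functional assay on SW480 cells (Homo sapiens) for cytotoxicity, read by MTT assay, with a stated time of 48 h (on this read-out lower numbers stand for stronger inhibition and higher numbers for weaker inhibition), compound 1 gives > 100000 nM, which is a limit of the assay and not a number; on the numbers shown compound 1 stands at the limit of > 100000 nM in this assay, at which 1 of the 3 values shown sits. Two further compounds carry a number. Compound 3 `O=c1ccoc2cc(OCc3cn(Cc4ccc([N+](=O)[O-])cc4)nn3)ccc12` gives 19300 nM in this assay, and compound 2 `CC(C)(C)c1ccc(Cn2cc(COc3ccc4c(=O)ccoc4c3)nn2)cc1` gives 28800 nM there. The two measured steps are an at least 5.1-fold lower number from compound 1 to compound 3 (0.71 log units; beyond the scatter) and a 1.5-fold lower number from compound 2 to compound 3 (0.17 log units; within the scatter).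

Compound 4 `N#Cc1ccc(Cn2cc(COc3ccc4c(=O)ccoc4c3)nn2)cc1` remains to be measured. Its difference from compound 1 is 4-cyanophenyl in place of 3-bromophenyl on a saturated chain carbon bound to an aromatic nitrogen. The step that bears on it most directly is an at least 5.1-fold lower number from compound 1 to compound 3 (0.71 log units; beyond the scatter), where a change at the same place, to a 4-nitrophenyl, moved the number off the limit. The second step, a 1.5-fold lower number from compound 2 to compound 3 (0.17 log units; within the scatter), shows that two different groups on the 4-position of that ring, nitro and tert-butyl, sit within the scatter of one another. Another 4-substituted ring is therefore expected to land near compounds 2 and 3, with a step of roughly an at least 4.0-fold lower number from compound 1 to compound 4 (0.60 log units; beyond the scatter) expected in this assay. For compound 4 the expected value in this assay is 25000 nM, estimated within 9000 nM to 70000 nM.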

Compound 4, half-maximal inhibitory concentration: > 100000 nM
Compound 4 gave a limit, no number; the forecaster's own chance of this, stated with the estimate: 12%; middle value at least 4.0-fold (0.60 log units) away from the limit.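

In this assay compound 4 sits, like compound 1, at a limit and not at a number, so the step between these two cannot be read: the limit of > 100000 nM in this assay, at which 2 of the 4 values shown sit.

At the same place, cyano in place of nitro on an aromatic carbon gives an at least 5.1-fold higher number from compound 3 to compound 4 (0.71 log units; beyond the scatter), and putting the cyano where the tert-butyl stood gives an at least 3.4-fold higher number from compound 2 to compound 4 (0.54 log units; beyond the scatter). Compounds 2 and 3 alone suggested that a 4-substituted ring was enough to come off the limit, but compound 4 goes against that reading, and the group carried by the ring now separates compounds within this small set.

The compounds shown leave open whether the change from 3-bromophenyl to 4-cyanophenyl has any effect at all, since both compounds sit at the limit. They also leave open how a 4-bromophenyl, a 4-aminophenyl or a 4-carboxyphenyl would read at this place, and so whether compounds 2 and 3 or compounds 1 and 4 are the more typical members of the series.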